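This account rests on a few compounds, and the source may have more. Where it says the series, first, only, none or still open, it means among the compounds named here.

Measured so far:
- Compound 1, `[O-][S+](CCNC1CCN(Cc2ccc(F)cc2)CC1)C(c1ccc(F)cc1)c1ccc(F)cc1`: 26.5 nM
- Compound 2, `O=C(c1ccccc1)N1CCC(NCC[S+]([O-])C(c2ccc(F)cc2)c2ccc(F)cc2)CC1`: 585 nM

These two values come from an assay on membranes from Cortex for displacement of a labelled ligand from Sigma non-opioid intracellular receptor 1 (Cavia porcellus), read by scintillation counting, with a stated time of 120 min; a lower number here means a stronger inhibitor, a higher number a weaker inhibitor. Among the measured compounds shown here, compound 2 has the highest of the two numbers, which makes it the weaker inhibitor of the pair; the only neighbour is compound 1, and the step of a 22-fold higher number from compound 1 to compound 2 (1.34 log units; beyond the scatter) separates them.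

Compound 3, `O=C(c1ccc(F)cc1)N1CCC(NCC[S+]([O-])C(c2ccc(F)cc2)c2ccc(F)cc2)CC1`, is not yet measured. It differs from compound 2 by fluoro in place of hydrogen on an aromatic carbon, placed on an aromatic carbon of a six-membered aromatic ring of carbon only, para to a large group. For the measured compounds named here, no measured step tests a fluoro in this part of the molecule; the one known step, a 22-fold higher number from compound 1 to compound 2 (1.34 log units; beyond the scatter), concerns a different change at the same ring nitrogen and so gives no direct guide. A single fluorine added on an aromatic ring is expected to move the number little, so for compound 3 the expected step is a 1.3-fold lower number from compound 2 to compound 3 (0.11 log units; within the scatter), within the scatter, and the estimate for compound 3 is 450 nM, with a range from 150 nM to 1500 nM.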

Compound 3, inhibition constant: 1440 nM
For compound 3 the middle estimate is 3.2-fold (0.51 log units) below the measured one; low and high end bracket the measured number.
By their numbers in this assay, from the lowest: compound 1; then compound 2; then compound 3.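

In this assay, the aromatic ring of the benzoyl group proves sensitive even to a very small change: fluoro in place of hydrogen, para to a large group, gives a 2.5-fold higher number from compound 2 to compound 3 (0.39 log units; beyond the scatter) and so counts as a modest but real step. This fluoro moves the number the same way as the earlier change at the ring nitrogen, and replacing 4-fluorobenzyl with (4-fluorophenyl)carbonyl gives a 54-fold higher number from compound 1 to compound 3 (1.74 log units; beyond the scatter) and so exceeds the step seen with benzoyl. Nothing available here accounts for the effect of this fluoro.

The compounds shown leave open whether a methoxy or an amine on that same aromatic carbon would also raise the number. On these data alone, they also do not show whether a plain benzyl on the ring nitrogen would differ from 4-fluorobenzyl, so the effect of fluoro on that side remains unknown.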